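The source may report more compounds than this note shows. Statements on the series, on what has been measured and on what is new or still open speak of the compounds shown alone.

Measured so far in a functional assay on brain (Rattus norvegicus, strain Wistar) for inhibition; a lower number here means a stronger inhibitor, a higher number a weaker inhibitor:
compound 1 `Cc1[nH]c(=O)n(C)c1-c1ccc(OC(C)C)cc1` gives 20400 nM;
compound 2 `Cc1[nH]c(=O)n(C)c1-c1ccc(CC(C)C)cc1` gives 7800 nM;
compound 3 `Cc1[nH]c(=O)n(C2CCCCC2)c1-c1ccc(OC(C)C)cc1` gives 13000 nM.

Compound 4 `Cc1[nH]c(=O)n(C2CCCCC2)c1-c1ccc(CC(C)C)cc1` has not yet been measured in this assay. Its core is that of compound 3, which differs from the core of compound 1 by cyclohexyl in place of methyl on an aromatic nitrogen; that change gave a 1.6-fold lower number from compound 1 to compound 3 (0.20 log units; within the scatter), so compound 1 and compound 3 cannot be told apart here.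

Compound 4 differs from compound 3 by isobutyl in place of isopropoxy on an aromatic carbon. The same kind of change has been measured once, between compound 1 and compound 2, where the structures differ by isobutyl in place of isopropoxy on an aromatic carbon; the surroundings are described slightly differently, para to a large group in one case and para to a group of 8 heavy atoms in the other, but the group that leaves and the group that enters are the same. That earlier step gave a 2.6-fold lower number from compound 1 to compound 2 (0.42 log units; beyond the scatter), a modest gain that lies beyond the usual scatter.

For the measured compounds named here, with only one prior example, a step of similar size is expected from compound 3 to compound 4 in this assay, namely a 2.6-fold lower number from compound 3 to compound 4 (0.41 log units; beyond the scatter), because compound 1 to compound 2 showed a 2.6-fold lower number from compound 1 to compound 2 (0.42 log units; beyond the scatter). Compound 4 is therefore estimated at 5000 nM, most likely between 2000 nM and 12000 nM.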

Compound 4, half-maximal inhibitory concentration: 10900 nM
The estimate for compound 4 lay 2.2-fold (0.34 log units) below the measured number, within the range that was stated.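

In this assay, for the compounds shown here, putting isobutyl in place of isopropoxy on the core of compound 3 gives a 1.2-fold lower number from compound 3 to compound 4 (0.08 log units; within the scatter), and this step cannot be told apart from the earlier one on the core of compound 1: the same change on two cores in this assay, a 2.6-fold lower number (0.42 log units; beyond the scatter) from compound 1 to compound 2 and a 1.2-fold lower number (0.08 log units; within the scatter) from compound 3 to compound 4, 2.2-fold (0.34 log units) apart, within the scatter of two such steps Putting cyclohexyl in place of methyl on the aromatic nitrogen gives a 1.4-fold higher number from compound 2 to compound 4 (0.15 log units; within the scatter), and this step also agrees with its earlier counterpart: the same change on two cores in this assay, a 1.6-fold lower number (0.20 log units; within the scatter) from compound 1 to compound 3 and a 1.4-fold higher number (0.15 log units; within the scatter) from compound 2 to compound 4, 2.2-fold (0.34 log units) apart, within the scatter of two such steps The two pairs for each change therefore show no measurable difference between cores, but they do not prove that each change carries over unchanged, since only the step from compound 1 to compound 2 lies beyond the scatter and two pairs per change are very few.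

The compounds shown leave open how an amine, a carboxylic acid or a longer chain would behave in place of isobutyl on the aromatic carbon. They also leave open whether an ethyl group or a cyclopentyl ring on the aromatic nitrogen would fit the same picture.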